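The compounds below may be only part of what the source reports. "The series", "measured", "known", "first", "only" and "open" are said of these compounds alone.

Measured compounds:
- compound 1, `CCCC(Oc1ccc(-n2cc3ccccc3n2)cc1)c1ccc(C(=O)NCCC(=O)O)cc1` — in an assay on cells for displacement of a labelled ligand from Glucagon receptor (Homo sapiens), in the presence of a further agent that is not named here (on this read-out higher numbers stand for weaker inhibition and lower numbers for stronger inhibition), compound 1 gives 290 nM
- compound 2, `CCCC(Nc1ccc(-n2cnc(C(F)(F)F)c2)cc1)c1ccc(C(=O)NCCC(=O)O)cc1` — in this assay compound 2 gives 680 nM

Among these two numbers, compound 1 stands lowest, and the gap to compound 2 lies beyond the usual scatter of repeat measurements. Compound 3, `CCCC(Oc1ccc(-n2cc(Cl)cn2)cc1)c1ccc(C(=O)NCCC(=O)O)cc1`, has not yet been measured. It differs from compound 1 in one place: 4-chloro-1H-pyrazol-1-yl in place of 2H-indazol-2-yl on an aromatic carbon. The group that leaves is a fused two-ring unit; the group that enters is a single five-membered ring carrying a chlorine. Nothing in the measured pair isolates this exchange on its own, since compound 2 also differs from compound 1 in its linker. A modest loss of binding strength is expected, so the step of a 2.2-fold higher number from compound 1 to compound 3 (0.35 log units; beyond the scatter) should lie beyond the scatter but not far beyond it. Compound 3 is estimated at 650 nM, with a plausible range from 220 nM to 2000 nM.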

Compound 3, inhibition constant: 1100 nM
Estimate against measurement, compound 3: 1.7-fold (0.23 log units) below, within the range that was stated.
By their numbers in this assay, from the lowest: compound 1; then compounds 2 and 3 (each within the scatter of the next).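

In this assay, replacing 2H-indazol-2-yl with 4-chloro-1H-pyrazol-1-yl gives a 3.8-fold higher number from compound 1 to compound 3 (0.58 log units; beyond the scatter). Within the data shown here, this is the first direct evidence that the group on this aromatic carbon, para to a large group, affects the reading, and here the fused two-ring unit gives the stronger inhibition. No available evidence explains this difference.

The exchange removes the six-membered aromatic ring and adds a chlorine at the same time, so the compounds shown leave open how much each change contributes; a plain pyrazol-1-yl group with no chlorine would help separate the two. On these data alone, it also remains open whether the same exchange would have a similar effect in a compound with the nitrogen linker of compound 2 in place of the oxygen linker of compound 1.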